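The compounds below may be only part of what the source reports. "The series", "measured", "known", "first", "only" and "open" are said of these compounds alone.

Measured compounds:
Compound 1 `N#Cc1ccc(Cn2cc(COc3ccc4c(=O)ccoc4c3)nn2)cc1`: in a functional assay on QGY7701 cells (Homo sapiens) for cytotoxicity, read by MTT assay, with a stated time of 48 h (a higher number here means a weaker inhibitor, a lower number a stronger inhibitor), compound 1 gives > 100000 nM, a limit of the assay.
Compound 2 `O=c1ccoc2cc(OCc3cn(Cc4ccc([N+](=O)[O-])cc4)nn3)ccc12`: in this assay compound 2 gives > 100000 nM, a limit.
Compound 3 `O=c1ccoc2cc(OCc3cn(Cc4ccccc4Br)nn3)ccc12`: in this assay compound 3 gives > 100000 nM, a limit.

For the measured compounds named here, every value so far sits at the limit of > 100000 nM in this assay, at which 3 of the 3 values shown sit, so compound 2 stands nowhere in particular: it is only a limit, as are the two others. The steps a step that the two limits leave unreadable from compound 1 to compound 2, a step that the two limits leave unreadable from compound 1 to compound 3 and a step that the two limits leave unreadable from compound 2 to compound 3 therefore cannot be sized, and none bears readably on the next change.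

Compound 4 `Cc1ccccc1Cn1cc(COc2ccc3c(=O)ccoc3c2)nn1` differs from compound 2 by 2-methylphenyl in place of 4-nitrophenyl on a saturated chain carbon bound to an aromatic nitrogen. With no readable step in this assay, no direction is expected; the step of a number no higher from compound 2 to compound 4 (the limit leaves the size open) is expected to be nil. Compound 4 is estimated at 100000 nM, between 30000 nM and 300000 nM, most probably reported again only as a limit.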

Compound 4, half-maximal inhibitory concentration: > 100000 nM
Compound 4 ended at the assay's limit (the forecaster's own chance of this, stated with the estimate: 80%); the middle value sits exactly at the limit.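

Compound 1, compound 2, compound 3 and compound 4 share one limit, so no step among them can be read: the limit of > 100000 nM in this assay, at which 4 of the 4 values shown sit.

The compounds shown leave open which change, if any, would give a measurable value in this assay.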